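This account rests on a few compounds, and the source may have more. Where it says the series, first, only, none or still open, it means among the compounds named here.

In an ADME assay on NIH3T3 cells (Mus musculus) for cytotoxicity, with a stated time of 72 h (a lower number here means a stronger inhibitor, a higher number a weaker inhibitor), compound 1 (`OC[C@H]1O[C@@H](n2cnc3c(NCc4ccc(Cl)cc4)ncnc32)[C@H](O)[C@@H]1O`) gives > 166000 nM, which is a limit of the assay and not a number. Compound 2 (`OC[C@H]1O[C@@H](n2cnc3c(NCc4ccc(F)cc4Cl)ncnc32)[C@H](O)[C@@H]1O`) gives > 166000 nM, which is likewise a limit. Compound 2 therefore has no exact position on the scale, and the only other result available for comparison is also a limit. Going by the values given here, the single measured step, a step that the two limits leave unreadable from compound 1 to compound 2, replaces 4-chlorophenyl with 2-chloro-4-fluorophenyl, but it offers no size to carry forward.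

Compound 3 (`OC[C@H]1O[C@@H](n2cnc3c(NCc4ccc(F)c(Cl)c4)ncnc32)[C@H](O)[C@@H]1O`) has 3-chloro-4-fluorophenyl in place of 2-chloro-4-fluorophenyl on a saturated chain carbon bound to a nitrogen on an aromatic ring. The evidence that bears on this change is the limit of > 166000 nM in this assay, at which 2 of the 2 values shown sit, which covers both compound 1 and compound 2. On that basis, no step beyond the scatter is expected in this assay, in either direction. The expected step is a number no higher from compound 2 to compound 3 (the limit leaves the size open), and it remains an estimate. Compound 3 is expected at 166000 nM, with an estimated range of 90000 nM to 300000 nM.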

Compound 3, half-maximal inhibitory concentration: > 166000 nM
Compound 3: only a limit was reported (the forecaster's own chance of this, stated with the estimate: 85%); the middle value lies on the limit itself.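

In this assay compound 3 gives > 166000 nM, which is a limit of the assay and not a number. Going by these compounds alone, no step between compound 1, compound 2 and compound 3 can be read, as all three results are limits. The compounds shown leave open whether 4-chlorophenyl, 2-chloro-4-fluorophenyl and 3-chloro-4-fluorophenyl differ at all in this assay.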